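A 2-phenylethenyl group on the shared core

The compounds below may be only part of what the source reports. "The series", "measured", "known", "first", "only" and "open" are said of these compounds alone.

In a functional assay on P388 cells (Mus musculus) for cytotoxicity (on this read-out higher numbers stand for weaker inhibition and lower numbers for stronger inhibition), compound 1 (`C=C(C)CN1C(=O)[C@@H](C)NC(=O)[C@@H]2Cc3ccc(OC)c(c3)Oc3ccc(cc3)C[C@@H](C(=O)N2C)N(C)C(=O)[C@H](C)NC(=O)[C@H](Cc2ccc(OC)cc2)N(C)C(=O)[C@@H]1C`) gives 11 nM, and compound 2 (`COc1ccc(C[C@H]2C(=O)N[C@@H](C)C(=O)N(C)[C@H]3Cc4ccc(cc4)Oc4cc(ccc4OC)C[C@@H](C(=O)N[C@H](C)C(=O)N(CC=C(C)C)[C@@H](C)C(=O)N2C)N(C)C3=O)cc1`) gives 6.92 nM. These two numbers lie within the usual scatter of each other, so compound 2 cannot be told apart from compound 1. Compound 3 (`COc1ccc(C[C@H]2C(=O)N[C@@H](C)C(=O)N(C)[C@H]3Cc4ccc(cc4)Oc4cc(ccc4OC)C[C@@H](C(=O)N[C@H](C)C(=O)N(C/C=C/c4ccccc4)[C@@H](C)C(=O)N2C)N(C)C3=O)cc1`) keeps the core of compound 2 and changes one group: 2-phenylethenyl in place of 2-methylprop-1-en-1-yl on a saturated chain carbon bound to an amide-type nitrogen in a ring. Going by the values given here, one measured step bears on this change, at the same place, on a saturated chain carbon bound to an amide-type nitrogen in a ring. It is a 1.6-fold lower number from compound 1 to compound 2 (0.20 log units; within the scatter), and it swaps 1-methylethenyl for 2-methylprop-1-en-1-yl. Neither of those groups holds an aromatic ring, so the data say little about 2-phenylethenyl. No shift beyond the scatter is therefore expected in this assay, though with real uncertainty. The expected step is a 1.4-fold higher number from compound 2 to compound 3 (0.16 log units; within the scatter). For compound 3 the estimated value is 10 nM, with an expected range of 3 nM to 35 nM.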

Compound 3, half-maximal inhibitory concentration: 10.7 nM
Compound 3: middle estimate off by 1.1-fold (0.03 log units), on the low side; measured number inside the range.
By their numbers in this assay, from the lowest: compounds 2, 3 and 1 (each within the scatter of the next).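

Compounds 1 and 2 carry only ring-free groups at this place, on a saturated chain carbon bound to an amide-type nitrogen in a ring, whereas compound 3 puts a six-membered aromatic ring there; in this assay this gives a 1.5-fold higher number from compound 2 to compound 3 (0.19 log units; within the scatter). Set against 1-methylethenyl, the same 2-phenylethenyl group gives a 1.0-fold lower number from compound 1 to compound 3 (0.01 log units; within the scatter), so in this assay the place accepts an aromatic ring, and a rise from 4 to 8 heavy atoms relative to 2-methylprop-1-en-1-yl, with no shift beyond the scatter. No available evidence accounts for this result.

As far as these compounds go, all three groups contain only carbon and hydrogen and have a double bond, so it remains open how an amine or a carboxylic acid would behave here. A fully saturated group such as 3-phenylpropyl is equally untested among these compounds.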